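This account rests on a few compounds, and the source may have more. Where it says the series, first, only, none or still open, it means among the compounds named here.

Measured so far in an assay on isolated protein for inhibition of matrix metalloproteinase-9 (Homo sapiens), read by fluorescence, with a stated time of 30 min; a higher number here means a weaker inhibitor, a lower number a stronger inhibitor:

compound 1 `Cc1ccc(S(=O)(=O)N(CCn2cc(CCCF)nn2)[C@@H](C(=O)NO)C(C)C)cc1`: 3 nM
compound 2 `Cc1ccc(S(=O)(=O)N(CCn2cc(CCCCOc3cccnc3F)nn2)[C@@H](C(=O)NO)C(C)C)cc1`: 6 nM
compound 3 `CC(C)[C@H](C(=O)NO)N(CCn1cc(CCCF)nn1)S(=O)(=O)c1ccc(OCCF)cc1`: 2 nM

Compound 2 differs from compound 1 by one change, (((2-fluoropyridin-3-yl)oxy)methyl in place of fluoro on a saturated chain carbon, three bonds along the chain from an aromatic carbon), and that change reads as a 2.0-fold higher number from compound 1 to compound 2 (0.30 log units; within the scatter). Compound 3 differs from compound 1 in the core, (2-fluoroethoxy in place of methyl on an aromatic carbon), with the step of a 1.5-fold lower number from compound 1 to compound 3 (0.18 log units; within the scatter). Compounds 2 and 3 are not connected by a single change; their two values in this assay simply stand a bit apart, the gap being beyond the scatter.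

Compound 4 `CC(C)[C@H](C(=O)NO)N(CCn1cc(CCCCOc2cccnc2F)nn1)S(=O)(=O)c1ccc(OCCF)cc1` is not yet measured. It differs from compound 3 by ((2-fluoropyridin-3-yl)oxy)methyl in place of fluoro on a saturated chain carbon, three bonds along the chain from an aromatic carbon, the same change as from compound 1 to compound 2, made at a place described in the same words, on the core of compound 3 rather than that of compound 1. In this assay the expected step is a 2.0-fold higher number from compound 3 to compound 4 (0.30 log units; within the scatter), resting on the earlier occurrence of this change, a 2.0-fold higher number from compound 1 to compound 2 (0.30 log units; within the scatter), which stayed within the scatter. Compound 4 is therefore expected at about 4 nM, with a likely range from 1.5 nM to 12 nM.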

Compound 4, half-maximal inhibitory concentration: 0.8 nM
Estimate against measurement, compound 4: 5.0-fold (0.70 log units) above, and the stated range ends above it.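

In this assay, the ((2-fluoropyridin-3-yl)oxy)methyl for fluoro change does not carry over as a fixed increment: on the core of compound 3 it gives a 2.5-fold lower number from compound 3 to compound 4 (0.40 log units; beyond the scatter), whereas the earlier step on the core of compound 1 stayed within the scatter: the same change on two cores in this assay, a 2.0-fold higher number (0.30 log units; within the scatter) from compound 1 to compound 2 and a 2.5-fold lower number (0.40 log units; beyond the scatter) from compound 3 to compound 4, 5.0-fold (0.70 log units) apart, beyond the scatter of two such steps.

The same four compounds read the other way show 2-fluoroethoxy in place of methyl giving a 7.5-fold lower number from compound 2 to compound 4 (0.88 log units; beyond the scatter), so the effect of that change depends on the group at the other end of the molecule: the same change on two cores in this assay, a 1.5-fold lower number (0.18 log units; within the scatter) from compound 1 to compound 3 and a 7.5-fold lower number (0.88 log units; beyond the scatter) from compound 2 to compound 4, 5.0-fold (0.70 log units) apart, beyond the scatter of two such steps.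

This shows that the two changes do not add independently across these four compounds, but it rests on a single set of two cores and does not give the reason for the departure or predict the step on any further core.

From the compounds shown here alone, it remains open whether the same dependence appears with ethoxy or chloro on the aromatic carbon in place of 2-fluoroethoxy. Also open, going by these compounds, is whether a phenyl or an unsubstituted pyridinyl in place of the 2-fluoropyridin-3-yl group would behave as compound 4 does.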